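From 4-fluorobenzyl to 4-bromobenzyl: notes on compound 4

The source may hold more compounds than are shown below. What is called first, only, known or untested is meant among the compounds shown, and "the series" means these compounds.

Measured so far in a functional assay on DU-145 cells (Homo sapiens) for inhibition, read by trypan blue exclusion, with a stated time of 96 h; a higher number here means a weaker inhibitor of growth, a lower number a stronger inhibitor of growth
- compound 1 `COc1cc(/C=C(/SCc2ccc(Br)cc2)C(=O)c2ccc(C(=O)O)cc2)ccc1F` gives 1000 nM
- compound 2 `O=C(O)c1ccc(C(=O)/C(=C\c2ccc(Cl)c([N+](=O)[O-])c2)SCc2ccc(C(F)(F)F)cc2)cc1` gives 1000 nM
- compound 3 `O=C(O)c1ccc(C(=O)/C(=C\c2ccc(Cl)c([N+](=O)[O-])c2)SCc2ccc(F)cc2)cc1` gives 1000 nM

In this assay compound 3 gives 1000 nM and stands level with compound 1 and compound 2, so the three measured compounds are not separated.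

The next compound is compound 4 `O=C(O)c1ccc(C(=O)/C(=C\c2ccc(Cl)c([N+](=O)[O-])c2)SCc2ccc(Br)cc2)cc1` and the change from compound 3 is bromo in place of fluoro on an aromatic carbon in the form of bromo in place of fluoro on an aromatic carbon, para to a large group. The same difference reads (4-fluorobenzyl)sulfanyl to (4-bromobenzyl)sulfanyl.

For the measured compounds named here, one measured step bears directly on this site. Fluoro in place of trifluoromethyl gave no change at the digits printed from compound 2 to compound 3 (within the scatter) and so the only exchange measured on this aromatic carbon moved nothing beyond the scatter. The 4-bromobenzyl group also occurs in compound 1, which gives 1000 nM and sits level with the other two. Going by the values given here, no measured compound shows a value away from this level, and the data hold no bromo-for-fluoro pair.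

A step of no change at the digits printed from compound 3 to compound 4 (within the scatter) is therefore expected in this assay with no direction favoured beyond the scatter. For compound 4 1000 nM is the estimated value, with 500 nM to 2000 nM as the expected range.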

Compound 4, concentration for 50% growth inhibition: 500 nM
Compound 4: middle estimate off by 2.0-fold (0.30 log units), on the high side; the measured number falls inside the stated range.
By their numbers in this assay, from the lowest: compounds 4, 1, 2 and 3 (each within the scatter of the next).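

In this assay, for the compounds shown here, the first direct bromo-for-fluoro pair on this aromatic carbon, para to a large group, gives a 2.0-fold lower number from compound 3 to compound 4 (0.30 log units; within the scatter), and bromo in place of trifluoromethyl at the same carbon gives a 2.0-fold lower number from compound 2 to compound 4 (0.30 log units; within the scatter); fluoro, trifluoromethyl and bromo are therefore not separated here beyond the scatter. With the 4-bromobenzyl group held constant, 4-chloro-3-nitrophenyl in place of 4-fluoro-3-methoxyphenyl gives a 2.0-fold lower number from compound 1 to compound 4 (0.30 log units; within the scatter), which extends the same reading to a second site in the series. No measurement that could account for these small steps accompanies the growth data.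

Whether this position can shift the number beyond the scatter remains open, as an amine or a hydroxyl on this aromatic carbon, or a longer chain in place of 4-bromobenzyl, would test a wider range of substituents than the three halogen-bearing groups shown. Going by these compounds, the role of the carboxylic acid on the shared core also remains open, and an amide or a nitrile in its place would address that question.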